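Third fluorine on the phenoxy tail of compound 2

The compounds below may be only part of what the source reports. "The series", "measured", "known", "first", "only" and "open" are said of these compounds alone.

Going by the values given here, compound 2 `NC(=O)c1ccn(-c2cccc(OC(=O)NCCOCCOc3ccc(F)cc3F)c2)c1` stands as the lowest of the two numbers so far in an assay (brain) for inhibition of Fatty-acid amide hydrolase 1 (Mus musculus), with stated times of 20 min and 15 min (on this read-out higher numbers stand for weaker inhibition and lower numbers for stronger inhibition), where compound 2 gives 28 nM. Its nearest neighbour, compound 1 `NC(=O)c1ccn(-c2cccc(OC(=O)NCCOCCOc3ccccc3F)c2)c1`, gives 69 nM in this assay. Among the compounds with values here, the one measured step, a 2.5-fold lower number from compound 1 to compound 2 (0.39 log units; beyond the scatter), is fluoro in place of hydrogen on an aromatic carbon of the phenoxy tail.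

The next compound, compound 3 `NC(=O)c1ccn(-c2cccc(OC(=O)NCCOCCOc3c(F)cc(F)cc3F)c2)c1`, is not yet measured. It differs from compound 2 by fluoro in place of hydrogen on an aromatic carbon, again fluoro in place of hydrogen on an aromatic carbon, this time on a carbon that is ortho to a large group and meta to two fluoro groups, so that 2,4-difluorophenoxy becomes 2,4,6-trifluorophenoxy.

Within the data shown here, only the step from compound 1 to compound 2 bears on this change; it was modest and beyond the scatter. A further fluorine on the same ring is expected to move the number in the same direction, though not necessarily by as much, so a small or modest drop is anticipated, a 1.6-fold lower number from compound 2 to compound 3 (0.19 log units; within the scatter). Compound 3 is therefore estimated at 18 nM in this assay, with a range from 8 nM to 45 nM.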

Compound 3, half-maximal inhibitory concentration: 43 nM
Estimate against measurement, compound 3: 2.4-fold (0.38 log units) below; measured number inside the range.
By their numbers in this assay, from the lowest: compounds 2, 3 and 1 (each within the scatter of the next, the first and the last beyond it).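

In this assay, fluoro in place of hydrogen on this carbon, ortho to a large group and meta to two fluoro groups, gives a 1.5-fold higher number from compound 2 to compound 3 (0.19 log units; within the scatter) and so leaves compound 3 not separable from compound 2. Set against the 2-fluorophenyl end of the series, the 2,4,6-trifluorophenyl group gives a 1.6-fold lower number from compound 1 to compound 3 (0.21 log units; within the scatter) and is not separable from compound 1 either, so the step beyond the scatter seen with a 2.5-fold lower number from compound 1 to compound 2 (0.39 log units; beyond the scatter) finds no continuation here, and the number of fluoro groups on the ring does not order these compounds in a single direction. No measurement shown accounts for this result.

The compounds shown leave open how a chloro, a methyl or a methoxy group would read on this same carbon, and where the unsubstituted phenoxy tail would fall relative to these compounds. Any trend with fluoro count rests on these few compounds alone, and a replicate-level difference between compound 2 and compound 3 cannot be resolved from the numbers at hand.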